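Sulfonyl aryl exchange in the sulfonamide series

The source may hold more compounds than are shown below. What is called first, only, known or untested is meant among the compounds shown, and "the series" means these compounds.

Compound 1 `Cc1cccc(-c2noc(C3CN(S(=O)(=O)c4cccc(C)c4)C3)n2)c1` is one of two compounds in the series with a number in an assay on HEK293 cells for negative allosteric modulation of metabotropic glutamate receptor 5 (Homo sapiens), read by FLIPR; on this read-out higher numbers stand for weaker inhibition and lower numbers for stronger inhibition; in this assay compound 1 gives 650 nM, the higher of the two numbers. Compound 3 `Cc1cccc(S(=O)(=O)N2CC(c3nc(-c4cccc(Cl)c4)no3)C2)c1` gives 390 nM, and the step of a 1.7-fold lower number from compound 1 to compound 3 (0.22 log units; within the scatter) stays within the scatter, so the two compounds are not separated. Compound 2 `O=C(N1CCC(F)CC1)N1CC(c2nc(-c3cccc(Cl)c3)no2)C1` is reported in this assay only as a limit, > 10000 nM, not as a number; that limit is the limit of > 10000 nM in this assay, at which 1 of the 3 values shown sits.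

Compound 4 `Cc1cccc(-c2noc(C3CN(S(=O)(=O)c4ccc(F)cc4)C3)n2)c1` differs from compound 1 in a single place: 4-fluorophenyl in place of 3-methylphenyl on a sulfonyl sulfur. For the measured compounds named here, no measured step touches the group on the sulfonyl sulfur. Going by the values given here, the one step on record, a 1.7-fold lower number from compound 1 to compound 3 (0.22 log units; within the scatter), concerns the other aromatic ring and was within the scatter, so it gives no direction for a change on the sulfonyl side. Nothing in the series therefore points to a move beyond the scatter either way. Compound 4 is expected to give 800 nM, with a range from 300 nM to 2500 nM. The estimated step is a 1.2-fold higher number from compound 1 to compound 4 (0.09 log units; within the scatter), essentially no change beyond the scatter.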

Compound 4, half-maximal inhibitory concentration: 950 nM
Compound 4: middle estimate off by 1.2-fold (0.07 log units), on the low side; measured number inside the range.
By their numbers in this assay, from the lowest: compounds 3, 1 and 4 (each within the scatter of the next, the first and the last beyond it). At a limit, above all of these: compound 2.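

In this assay the group on the sulfonyl sulfur now has a step of its own, and 4-fluorophenyl in place of 3-methylphenyl gives a 1.5-fold higher number from compound 1 to compound 4 (0.16 log units; within the scatter) and so leaves the two compounds unseparated. The two aryl groups differ both in the substituent and in its place on the ring, yet the step stays within the scatter, though a single exchange cannot show that this place is insensitive to change in general. No available evidence bears on this result.

Open, on these data alone, is whether a different kind of group on the sulfonyl sulfur, such as a pyridyl ring, a cyclopropyl or a plain methyl, would move the number beyond the scatter. Also open, as far as these compounds go, is whether an amine or a carboxylic acid on the sulfonyl aryl ring would do so.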